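The source may report more compounds than this note shows. Statements on the series, on what has been measured and on what is new or still open speak of the compounds shown alone.

Working notes on the series, cytotoxicity arm.

Compound 1 `CC(C)[C@H](NC(=O)[C@]1(Cc2ccccc2)CCN1C(=O)OCc1ccccc1)C(N)=O` gives, in an ADME assay on HELF cells (Homo sapiens) for cytotoxicity, with a stated time of 3 days (on this read-out higher numbers stand for lower toxicity in this test and lower numbers for higher toxicity in this test), 100000 nM. Compound 2 `C[C@H](NC(=O)[C@]1(Cc2ccccc2)CCN1C(=O)Oc1cccc2ccccc12)C(N)=O` gives in this assay only a limit, > 100000 nM; that such a limit appears in the set is noted as the limit of > 100000 nM in this assay, at which 1 of the 3 values shown sits. Compound 3 `CC(C)[C@H](NC(=O)[C@@]1(Cc2ccccc2)CCN1C(=O)OCc1ccccc1)C(N)=O` gives in this assay 85000 nM. Compound 3 stands next to compound 1: the step of a 1.2-fold lower number from compound 1 to compound 3 (0.07 log units; within the scatter), which rests on the fact that the two differ only in configuration as drawn (the fact that compounds 1 and 3 differ only in the configuration as drawn), is within the scatter. Among the compounds with values here, the two numbers so far, and the one limit, all sit at the top end of the range this assay reports.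

Compound 4 `C[C@H](NC(=O)[C@@]1(Cc2ccccc2)CCN1C(=O)OCc1ccccc1)C(=O)NC1CCCCC1` is the next structure. The change from compound 3 is 1-(cyclohexylcarbamoyl)ethyl in place of 1-carbamoyl-2-methylpropyl on an amide-type nitrogen. Within the data shown here, no measured step covers this kind of change; the only step in hand, from compound 1 to compound 3, is a stereochemical one and was within the scatter. With nothing pointing either way, no step beyond the scatter is expected in this assay, and compound 4 is expected at 70000 nM, between 25000 nM and 150000 nM, an expected step of a 1.2-fold lower number from compound 3 to compound 4 (0.08 log units; within the scatter) from compound 3.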

Compound 4, half-maximal cytotoxic concentration: 46000 nM
For compound 4 the middle estimate is 1.5-fold (0.18 log units) above the measured one; the measured number falls inside the stated range.
By their numbers in this assay, from the lowest: compounds 4, 3 and 1 (each within the scatter of the next, the first and the last beyond it).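

Within the data shown here, this is the first change at the amide-type nitrogen rather than in configuration as drawn, and in this assay it gives a 1.8-fold lower number from compound 3 to compound 4 (0.27 log units; within the scatter). The exchange of 1-carbamoyl-2-methylpropyl for 1-(cyclohexylcarbamoyl)ethyl brings in a six-membered non-aromatic ring of carbon only, where the leaving group has no ring, while the hydrogen-bond donor and acceptor counts stay the same, so at this position such a ring is carried without a step beyond the scatter. Nothing in hand bears on what lies behind this step.

Going by these compounds, how the step divides between the cyclohexyl ring and the rest of the exchange stays open. Also open, on these data alone, is whether an amine or a carboxylic acid in place of that ring would give a step beyond the scatter in this assay.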